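Changing the aryl group on the amide-type nitrogen

The source may hold more compounds than are shown below. What is called first, only, known or untested is meant among the compounds shown, and "the series" means these compounds.

Compound 1, `CNC(=O)c1ccc(Oc2cccc(NC(=S)Nc3ccc(OC(F)(F)F)cc3)c2)nc1`: in a functional assay on MDA-MB-231 cells (Homo sapiens) for antiproliferative activity, read by MTT assay (a lower number here means a stronger inhibitor, a higher number a weaker inhibitor), compound 1 gives 56000 nM.
Compound 2, `CNC(=O)c1ccc(Oc2cccc(NC(=S)Nc3ccc(C)c(C)c3)c2)nc1`: in this assay compound 2 gives 38600 nM.
Compound 3, `CNC(=O)c1ccc(Oc2cccc(NC(=S)Nc3ccc(F)c(Cl)c3)c2)nc1`: in this assay compound 3 gives 28600 nM.

Among the measured compounds shown here, compound 3 has the lowest of the three numbers, but its nearest neighbour, compound 2, sits within the scatter of it, and compound 1 also sits within the scatter of compound 3, so no compound can be called the strongest on these data. For the measured compounds named here, the one step that differs in a single place, a 1.3-fold lower number from compound 2 to compound 3 (0.13 log units; within the scatter), is within the scatter.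

Compound 4, `CNC(=O)c1ccc(Oc2cccc(NC(=S)Nc3ccc(OC)cc3)c2)nc1`, has not yet been measured. It differs from compound 3 in one place: 4-methoxyphenyl in place of 3-chloro-4-fluorophenyl on an amide-type nitrogen. The step from compound 2 to compound 3 bears on this change, as it also swaps the aryl group on the same amide-type nitrogen, and it was small. The values of compound 1 and compound 3, which differ in the aryl group on that nitrogen as well, lie within the scatter of each other. No change of this kind has produced a step beyond the scatter here, so compound 4 is expected to stay in the same region, with a 1.6-fold higher number from compound 3 to compound 4 (0.20 log units; within the scatter) expected to lie within the scatter. Compound 4 is estimated at 45000 nM, with a range from 20000 nM to 100000 nM.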

Compound 4, half-maximal inhibitory concentration: 31500 nM
Compound 4: the middle estimate sits 1.4-fold (0.15 log units) above what was measured; low and high end bracket the measured number.
By their numbers in this assay, from the lowest: compounds 3, 4, 2 and 1 (each within the scatter of the next).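

In this assay, 4-methoxyphenyl on the amide-type nitrogen whose other neighbour is the thiocarbonyl carbon brings a hydrogen-bond acceptor that 3-chloro-4-fluorophenyl lacks, yet the result is a 1.1-fold higher number from compound 3 to compound 4 (0.04 log units; within the scatter) and so shows no measurable effect of this swap. Among the compounds shown here, the comparisons with the other two aryl groups read the same way, with 3,4-dimethylphenyl giving a 1.2-fold lower number from compound 2 to compound 4 (0.09 log units; within the scatter) and the change of methyl for trifluoromethyl on an oxygen on an aromatic ring, seen here for the first time as a change in that one group alone, giving a 1.8-fold lower number from compound 1 to compound 4 (0.25 log units; within the scatter). All four aryl groups on this nitrogen therefore fall within the scatter of their neighbours in the ordering, and nothing available gives an independent measurement that could account for this.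

Going by these compounds, what stays open is whether any group on this nitrogen can move the number beyond the scatter, for instance an aryl group carrying an amine or a carboxylic acid, or a longer chain in place of the methyl on the oxygen. The compounds shown also leave open whether the same insensitivity holds when the methyl on the amide at the other end of the core is replaced by a longer chain.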